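Swapping a Methylsulfonyl for a Cyano Group

A few compounds are considered here, and "the series" means these few. Any claim that something is new, unique, unknown or untested is made for them only; others in the source may bear on it.

Compound 2 `CS(=O)(=O)c1ccc(COc2ccc(-c3c(N)nc(N)nc3COCc3ccccc3)cc2)cc1` was tested in an in vitro assay on CHOK cells for displacement of a labelled ligand from growth hormone secretagogue receptor type 1 (Homo sapiens) (a higher number here means a weaker inhibitor, a lower number a stronger inhibitor), where compound 2 gives 6.9 nM. Compound 1 `Nc1nc(N)c(-c2ccc(NCc3csc(Cl)c3)cc2)c(COCc2ccccc2)n1` gives 6.3 nM in this assay; the two numbers sit within the scatter of each other, so neither can be called the stronger binder. Compound 3 `N#Cc1ccc(COc2ccc(-c3c(N)nc(N)nc3COCc3ccccc3)cc2)cc1` differs from compound 2 in one place: cyano in place of methylsulfonyl on an aromatic carbon. Going by the values given here, no measured pair shows this change, so its effect is unknown. The expected shift, a 1.3-fold higher number from compound 2 to compound 3 (0.12 log units; within the scatter), is small and no larger than the scatter. Compound 3 is therefore estimated at 9 nM, within a range from 3 nM to 30 nM.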

Compound 3, half-maximal inhibitory concentration: 83 nM
Compound 3: the middle estimate sits 9.2-fold (0.96 log units) below what was measured, outside the stated range (above it).
By their numbers in this assay, from the lowest: compounds 1 and 2 (each within the scatter of the next); then compound 3.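

Putting cyano in place of methylsulfonyl on this aromatic carbon gives a 12-fold higher number from compound 2 to compound 3 (1.08 log units; beyond the scatter) in this assay and so shows that this position is sensitive to the group it carries. The (4-cyanobenzyl)oxy group also falls short of the ((5-chlorothiophen-3-yl)methyl)amino group, with a 13-fold higher number from compound 1 to compound 3 (1.12 log units; beyond the scatter) in this assay on the same kind of carbon. Nothing at hand gives a reason for either step.

Going by these compounds, it remains open whether methylsulfonyl is unusually well accepted here or cyano is the exception. A sulfonamide, a primary amide or a plain hydrogen on this carbon would help to settle that.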